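A few compounds are considered here, and "the series" means these few. Any claim that something is new, unique, unknown or untested is made for them only; others in the source may bear on it.

In a functional assay on MCF7 cells (Homo sapiens) for inhibition, read by MTT assay, with a stated time of 72 h (on this read-out higher numbers stand for weaker inhibition and lower numbers for stronger inhibition), compound 1 `CCCc1ccc(NC(=O)C2CCN(C/C=C/c3ccccc3)CC2)cc1` gives 9030 nM, while compound 2 `O=C(Nc1cccc(F)c1)C1CCN(C/C=C/c2ccccc2)CC1` gives 33000 nM, the higher of the two numbers and so the weaker inhibition. Compound 3 `O=C(Nc1ccc(F)c(Br)c1)C1CCN(C/C=C/c2ccccc2)CC1` keeps the shared core of compound 2 and differs by 3-bromo-4-fluorophenyl in place of 3-fluorophenyl on an amide-type nitrogen. Going by the values given here, only one measured step bears on this place, a 3.7-fold higher number from compound 1 to compound 2 (0.56 log units; beyond the scatter), and it is modest but beyond the scatter. Among the compounds with values here, it involves a different group, and no measured compound carries bromine, so it offers only a rough guide to size. Compound 2 sits at the high end of the two numbers, so a modest step towards a lower number is expected in this assay. This estimate means a 2.2-fold lower number from compound 2 to compound 3 (0.34 log units; beyond the scatter). The expected value for compound 3 is 15000 nM, with an estimated range of 6000 nM to 40000 nM.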

Compound 3, half-maximal inhibitory concentration: 13500 nM
Compound 3: middle estimate off by 1.1-fold (0.05 log units), on the high side, within the range that was stated.
By their numbers in this assay, from the lowest: compounds 1 and 3 (each within the scatter of the next); then compound 2.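

In this assay, going by these compounds alone, the earlier compounds left open whether a phenyl ring carrying only halogens on the amide-type nitrogen would always give the weaker inhibition, and the change to 3-bromo-4-fluorophenyl gives a 2.4-fold lower number from compound 2 to compound 3 (0.39 log units; beyond the scatter), a modest gain in inhibition. The comparison with the 4-propylphenyl group gives a 1.5-fold higher number from compound 1 to compound 3 (0.17 log units; within the scatter), so these two different groups cannot be told apart in this assay, and the propyl chain is not needed to reach this level among the compounds shown. Nothing available explains either step.

The change brings in bromine and adds a second halogen in a single step, so 3-bromophenyl and 4-fluorophenyl would be needed to separate the two contributions. As far as these compounds go, how an amine, a carboxylic acid or a chain longer than propyl on this ring would behave also remains open.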